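The source may report more compounds than this note shows. Statements on the series, on what has been measured and on what is new or still open speak of the compounds shown alone.

Working notes on the series in a functional assay on B16 cells (Mus musculus) for cytotoxicity, read by MTT assay, with a stated time of 72 h; a higher number here means a weaker inhibitor, a lower number a stronger inhibitor.

Compound 1 `COc1ccc(/C=C/C(=O)Nc2cc(C(=O)c3cc(OC)c(OC)c(OC)c3)ccc2OC)cc1` gives 8700 nM in this assay. Compound 2 `COc1cccc(/C=C/C(=O)Nc2cc(C(=O)c3cc(OC)c(OC)c(OC)c3)ccc2OC)c1` gives 3100 nM in this assay, the step being a 2.8-fold lower number from compound 1 to compound 2 (0.45 log units; beyond the scatter). Within the two numbers shown, compound 2 holds the lower value, and compound 1 sits at the other end of that step.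

Compound 3 `COc1cccc(/C=C/C(=O)Nc2cc(C(=O)c3cc(OC)c(OC)c(OC)c3)cc(OC)c2OC)c1` differs from compound 2 by methoxy in place of hydrogen on an aromatic carbon. Among the compounds with values here, no measured step bears directly on this change: the only step recorded, a 2.8-fold lower number from compound 1 to compound 2 (0.45 log units; beyond the scatter), concerns a shift of the methoxy group on the other aryl part of the shared core, not an added methoxy on the ring described here. With nothing to lean on, the expectation for the step from compound 2 to compound 3 is none beyond the scatter, expressed as a 1.0-fold lower number from compound 2 to compound 3 (0.01 log units; within the scatter). The estimate for compound 3 in this assay is 3000 nM, expected to fall between 1200 nM and 8000 nM.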

Compound 3, half-maximal inhibitory concentration: 6700 nM
Estimate against measurement, compound 3: 2.2-fold (0.35 log units) below; the measured number falls inside the stated range.
By their numbers in this assay, from the lowest: compound 2; then compounds 3 and 1 (each within the scatter of the next).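

In this assay, methoxy in place of hydrogen on this aromatic carbon, ortho to a methoxy group and meta to two large groups, gives a 2.2-fold higher number from compound 2 to compound 3 (0.33 log units; beyond the scatter) and so costs a modest amount of activity. Within the data shown here, the earlier step, a 2.8-fold lower number from compound 1 to compound 2 (0.45 log units; beyond the scatter), moved a methoxy group on the other aryl part, whereas this result is the first to test a substituent on this six-membered aromatic ring, and here hydrogen gives the lower number of the two groups compared. Nothing available accounts for this difference.

Going by these compounds, it remains open whether the change is specific to methoxy or would also appear with a smaller or different group on the same carbon, such as fluorine, a hydroxyl group or an amine. On these data alone, it is also open whether a longer chain, such as ethoxy, would move the number further from that of compound 2.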